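This account rests on a few compounds, and the source may have more. Where it says the series, first, only, none or still open, it means among the compounds named here.

The study sets four compounds on one shared core, varying only the group on an aromatic carbon. Compound 1 `CCOC(=O)CCCCCOc1cccc(CN(C(=O)c2ccc(-c3ccncc3)cc2)C(C)C)c1` carries pyridin-4-yl on that carbon, compound 2 `CCOC(=O)CCCCCOc1cccc(CN(C(=O)c2ccc(-c3cccc(OCC(C)C)c3)cc2)C(C)C)c1` carries 3-(isobutoxy)phenyl, and compound 3 `CCOC(=O)CCCCCOc1cccc(CN(C(=O)c2ccc(-c3ccc4cc[nH]c4c3)cc2)C(C)C)c1` carries 1H-indol-6-yl. In an ADME assay on Raji cells (Homo sapiens) for cytotoxicity, read by CellTiter-Glo and resazurin assay, with a stated time of 72 h (a higher number here means that more compound is needed for the effect, a lower number that less compound is needed), compound 1 gives only a limit of the assay, > 26000 nM. In this assay compound 2 likewise gives a limit, > 26000 nM. Compound 3 also reaches only a limit in this assay, > 26000 nM. Compound 3 thus stands at the same limit as the other two, because of the limit of > 26000 nM in this assay, at which 3 of the 3 values shown sit. The steps a step that the two limits leave unreadable from compound 1 to compound 2, a step that the two limits leave unreadable from compound 1 to compound 3 and a step that the two limits leave unreadable from compound 2 to compound 3 are therefore of unreadable size.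

Compound 4 `CCOC(=O)CCCCCOc1cccc(CN(C(=O)c2ccc(-c3cccc([N+](=O)[O-])c3)cc2)C(C)C)c1` differs from compound 3 by 3-nitrophenyl in place of 1H-indol-6-yl on an aromatic carbon. The three measured steps are the ones that bear on this change, and none of them has a readable size; every exchange of the group on that aromatic carbon left the value at the limit, as the limit of > 26000 nM in this assay, at which 3 of the 3 values shown sit, shows. One therefore expects no step beyond the scatter in this assay, the expected step being a step that the limit leaves unreadable from compound 3 to compound 4. Compound 4 is accordingly estimated to sit again at the limit, at 30000 nM, within a range from 20000 nM to 100000 nM.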

Compound 4, half-maximal effective concentration: > 26000 nM
Compound 4: no number, only a limit; the forecaster's own chance of this, stated with the estimate: 85%; the middle value lies beyond the limit too.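

In this assay compound 4 gives only a limit (> 26000 nM). Within the data shown here, no new step can therefore be read between compound 4 and compound 1, compound 2 or compound 3: the limit of > 26000 nM in this assay, at which 4 of the 4 values shown sit. The compounds shown leave open whether exchanging the group on that aromatic carbon changes the read-out at all.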